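The source may report more compounds than this note shows. Statements on the series, on what has been measured and on what is new or still open speak of the compounds shown alone.

Compound 1 `Cc1c(C(=O)N/N=C\c2ccc(O)cc2)oc2cccc(O)c12` is the weakest of the three measured compounds in a functional assay on PC-3 cells (Homo sapiens) for inhibition (a higher number here means a weaker inhibitor, a lower number a stronger inhibitor), where compound 1 gives 21700 nM. Its nearest neighbour is compound 3 `Cc1c(C(=O)N/N=C\c2cccc(F)c2O)oc2cccc(O)c12`, which gives 12700 nM in this assay, and the step of a 1.7-fold lower number from compound 1 to compound 3 (0.23 log units; within the scatter) stays within the scatter. The furthest is compound 2 `Cc1c(C(=O)N/N=C\c2cc(Cl)ccc2O)oc2cccc(O)c12`, which gives 3120 nM in this assay, a modest gain recorded as a 7.0-fold lower number from compound 1 to compound 2 (0.84 log units; beyond the scatter). The unmeasured compound 4 `Cc1c(C(=O)N/N=C\c2cccnc2)oc2cccc(O)c12` differs from compound 1 in one place: pyridin-3-yl in place of 4-hydroxyphenyl on a carbon with a double bond to nitrogen. Both known steps swap the aryl group on the same carbon; one is modest, one within the scatter, and neither involves a pyridin-3-yl. Compound 4 is therefore expected to land near compound 1, with the step of a 1.2-fold higher number from compound 1 to compound 4 (0.06 log units; within the scatter) not clearly beyond the scatter. Compound 4 is estimated at 25000 nM, within 8000 nM to 80000 nM.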

Compound 4, half-maximal inhibitory concentration: >= 40000 nM
Compound 4: no number, only a limit; the forecaster's own chance of this, stated with the estimate: 15%; middle value at least 1.6-fold (0.20 log units) away from the limit.
By their numbers in this assay, from the lowest: compound 2; then compounds 3 and 1 (each within the scatter of the next). At a limit, above all of these: compound 4.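

Compound 4 has no number in this assay, only a limit of the assay: the limit of >= 40000 nM in this assay, at which 1 of the 4 values shown sits. On this carbon, pyridin-3-yl, with 0 hydrogen-bond donors, falls clearly behind both substituted 2-hydroxyphenyl groups, with an at least 3.1-fold higher number from compound 3 to compound 4 (0.49 log units; beyond the scatter) and an at least 12-fold higher number from compound 2 to compound 4 (1.10 log units; beyond the scatter). Against the 4-hydroxyphenyl group, however, an at least 1.8-fold higher number from compound 1 to compound 4 (0.26 log units; that floor lies within the scatter) does not establish a loss.

The compounds shown leave open how a simple phenyl, an aminophenyl or a chlorophenyl would read on this carbon. They also cannot separate the part played by the chlorine in compound 2 from that of the hydroxyl group.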